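Two inactive compounds and one still to test

The source may hold more compounds than are shown below. What is called first, only, known or untested is meant among the compounds shown, and "the series" means these compounds.

Compound 1 `COc1cccc(-c2ncnn2-c2cc(OC)c(OC)c(OC)c2)c1` gives > 10000 nM as a limit
Compound 2 `COc1cc(-c2ncnn2-c2ccc(Cl)cc2)cc(OC)c1OC` gives > 10000 nM as a limit

In a functional assay on MCF7 cells (Homo sapiens) for antiproliferative activity, read by MTT assay, with a stated time of 72 h (a lower number here means a stronger inhibitor, a higher number a weaker inhibitor), compound 1 stands at its limit of > 10000 nM and has no exact number. The data so far show only the limit of > 10000 nM in this assay, at which 2 of the 2 values shown sit, and nothing finer. Compound 3 `COc1cc(-n2ncnc2-c2ccccc2)cc(OC)c1OC` has not yet been measured. It differs from compound 1 by hydrogen in place of methoxy on an aromatic carbon meta to a large group, the change from 3-methoxyphenyl to phenyl. Going by the values given here, no measured pair shows this change, so no step beyond the usual scatter is expected in this assay and neither direction is favoured. The expected step is a step that the limit leaves unreadable from compound 1 to compound 3 and remains an estimate. For compound 3 the estimated value is 12000 nM with an expected range from 4000 nM to 40000 nM and a report as a limit is likely.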

Compound 3, half-maximal inhibitory concentration: > 10000 nM
Compound 3: only a limit was reported (the forecaster's own chance of this, stated with the estimate: 75%); the middle value lies beyond the limit too.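

No step can be read from compound 1 to compound 3 in this assay, as both stand only as limits: the limit of > 10000 nM in this assay, at which 3 of the 3 values shown sit. The compounds shown leave open whether hydrogen in place of methoxy changes activity at all, since none of the three has an exact number.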